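Nitro to methoxy: outlook for compound 3

The source may report more compounds than this note shows. Statements on the series, on what has been measured and on what is new or still open speak of the compounds shown alone.

Within the data shown here, compound 2 `Nc1scc(-c2cccc([N+](=O)[O-])c2)c1C(=O)c1ccc(Cl)cc1` stands lowest of the two numbers so far: in a functional assay on CHO cells for agonist activity at adenosine receptor A1 (Homo sapiens), read by fluorescence and ERK phosphorylation, with stated times of 30 min and 1.5 h, tested at 10 uM (on this read-out lower numbers stand for a weaker effect and higher numbers for a stronger effect at the one concentration tested), compound 2 gives 42%. Among the measured compounds shown here, its nearest neighbour is compound 1 `Nc1scc(-c2ccccc2)c1C(=O)c1ccc(Cl)cc1`, which in this assay gives 64%; the only measured step, a number 22 percentage points lower from compound 1 to compound 2 (beyond the scatter), is beyond the scatter and sets the scale of what one substituent on this ring can do. Compound 3 `COc1cccc(-c2csc(N)c2C(=O)c2ccc(Cl)cc2)c1` carries the change (methoxy in place of nitro on an aromatic carbon). For the measured compounds named here, no measured pair compares methoxy with nitro, so the bearing of the measured step is indirect: it shows that adding nitro cost a modest amount, and taking it away again could recover part of that, while the entering methoxy has no precedent. Compound 3 is therefore expected to land between the two measured numbers, with a number 11 percentage points higher from compound 2 to compound 3 (beyond the scatter) as the estimated step. The estimate for compound 3 is 53%, in the range 32% to 74%.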

Compound 3, a percentage reported as activity, at one concentration (the size of the read-out at that concentration, not a potency): 60%
Estimate against measurement, compound 3: 7 percentage points below; measured number inside the range.
By their numbers in this assay, from the lowest: compound 2; then compounds 3 and 1 (each within the scatter of the next).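

In this assay the step of a number 18 percentage points higher from compound 2 to compound 3 (beyond the scatter) shows that the number at this aromatic carbon, meta to a large group, depends on which group sits there, and not only on whether the carbon is substituted. With methoxy in place of hydrogen, the step of a number 4 percentage points lower from compound 1 to compound 3 (within the scatter) shows that this carbon can carry a substituent without a change beyond the scatter, so among the groups shown the drop belongs to nitro alone. No measurement here explains the difference between nitro and methoxy.

From the compounds shown here alone, whether any group at this carbon can lift the number beyond the scatter of compound 1 stays open. An amine, a carboxylic acid or a longer chain such as ethoxy would show how far the tolerance for methoxy extends.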